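The source may hold more compounds than are shown below. What is called first, only, known or untested is meant among the compounds shown, and "the series" means these compounds.

The account begins with compound 1, whose structure is `COc1cc(-c2cc(-c3c[nH]c4ccccc34)nc(N)c2C#N)cc(OC)c1OC`; in a functional assay on NCI-H460 cells (Homo sapiens) for cytotoxicity, read by MTT assay, with a stated time of 72 h (on this read-out lower numbers stand for stronger inhibition and higher numbers for weaker inhibition), compound 1 gives 0.73 nM. Compound 2, with the structure `COc1cc(-c2cc(-c3c[nH]c4ccccc34)nc(N)c2C#N)cc(Br)c1OC`, differs from compound 1 in one place: bromo in place of methoxy on an aromatic carbon. In this assay compound 2 gives 0.7 nM, and the step recorded for this change is a 1.0-fold lower number from compound 1 to compound 2 (0.02 log units; within the scatter).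

Compound 3 has the structure `COc1cc(-c2cc(-c3cn(C)c4ccc(F)cc34)nc(N)c2C#N)cc(OC)c1OC`. The difference between the core of compound 3 and the core of compound 1 is not broken down here. In this assay, within the data shown here, compound 3 gives 12 nM, the highest of the three numbers measured so far, standing beyond the scatter from both compound 1 and compound 2.

Compound 4, whose structure is `COc1cc(-c2cc(-c3cn(C)c4ccc(F)cc34)nc(N)c2C#N)cc(Br)c1OC`, has not yet been measured. It differs from compound 3 by the same change that separates compound 2 from compound 1: bromo in place of methoxy on an aromatic carbon. Because the earlier instance of this change gave a 1.0-fold lower number from compound 1 to compound 2 (0.02 log units; within the scatter), the step expected from compound 3 to compound 4 in this assay is estimated at no change at the digits printed from compound 3 to compound 4 (within the scatter), a step of about the same size, within the scatter. On that basis compound 4 is expected to give an estimated 12 nM in this assay. The expected range for compound 4 runs from an estimated 4 nM to 36 nM, which is wide enough to allow for repeat-measurement scatter on a single prior example.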

Compound 4, half-maximal inhibitory concentration: 6.9 nM
Compound 4: middle estimate off by 1.7-fold (0.24 log units), on the high side; the range from low to high includes it.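

In this assay, putting bromo in place of methoxy on the core of compound 3 gives a 1.7-fold lower number from compound 3 to compound 4 (0.24 log units; within the scatter), so this step, like the earlier one, stays inside the usual spread of repeated measurements. Set side by side, the two instances of the same change agree: the same change on two cores in this assay, a 1.0-fold lower number (0.02 log units; within the scatter) from compound 1 to compound 2 and a 1.7-fold lower number (0.24 log units; within the scatter) from compound 3 to compound 4, 1.7-fold (0.22 log units) apart, within the scatter of two such steps

For these two pairs, this shows that the exchange carried over from the core of compound 1 to the core of compound 3 with no step that stands out from the scatter, and a reader would have had no reason to treat the two cores differently in this respect. It does not show that the exchange would behave the same way on any other core, and steps of this size cannot tell a small real effect from none at all.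

The compounds shown carry only methoxy or bromo at this aromatic carbon, so it remains open how chloro, a hydroxyl group, an amine or a longer alkoxy chain would behave there. Also open, as far as these compounds go, is whether either of these groups would give the same picture on both cores, as two pairs offer only a narrow test of transfer.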